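A Single Fluoro Added to Compound 2

A few compounds are considered here, and "the series" means these few. Any claim that something is new, unique, unknown or untested is made for them only; others in the source may bear on it.

compound 1 `COc1cc(NC(=O)NNc2cc(-c3ccccc3)c3cnn(C)c3n2)cc(Cl)n1`: 31300 nM
compound 2 `Cn1ncc2c(-c3ccccc3)cc(NNC(=O)Nc3cc(Cl)nc(Cl)c3)nc21`: 6240 nM
compound 3 `Cc1nn(C)c2nc(NNC(=O)Nc3cc(Cl)nc(Cl)c3)cc(-c3ccccc3)c12`: 80000 nM

These three values come from a functional assay on HCT-116 cells (Homo sapiens) for cytotoxicity, read by MTT assay, with a stated time of 48 h, in the presence of a further agent that is not named here; on this read-out higher numbers stand for an effect only at larger amounts of compound and lower numbers for an effect already at smaller amounts. Among them, compound 2 has the lowest number, 6240 nM, so it makes a natural reference point.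

Compound 4 `Cn1ncc2c(-c3ccc(F)cc3)cc(NNC(=O)Nc3cc(Cl)nc(Cl)c3)nc21` differs from compound 2 in one place: fluoro in place of hydrogen on an aromatic carbon. In words, this is fluoro in place of hydrogen on an aromatic carbon, which turns phenyl to 4-fluorophenyl.

Two measured steps offer some guidance, though neither touches this ring. Replacing methoxy with chloro on an aromatic carbon gave a modest change, a 5.0-fold lower number from compound 1 to compound 2 (0.70 log units; beyond the scatter). Placing methyl in place of hydrogen on an aromatic carbon gave a large one, a 13-fold higher number from compound 2 to compound 3 (1.11 log units; beyond the scatter). Together they show that small edits can matter in this short series, but they say nothing about the direction of a change at the new place. Among the measured compounds shown here, with no measured example of this edit, no step beyond the scatter is expected in this assay. The estimated step is a 1.0-fold lower number from compound 2 to compound 4 (0.02 log units; within the scatter). The expected range stays wide because of a 13-fold higher number from compound 2 to compound 3 (1.11 log units; beyond the scatter). For compound 4 the estimated value is 6000 nM, with an expected range from 2000 nM to 20000 nM.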

Compound 4, half-maximal effective concentration: 8210 nM
Beside the measured number, compound 4's estimate is 1.4-fold (0.14 log units) below it; the range from low to high includes it.
By their numbers in this assay, from the lowest: compounds 2 and 4 (each within the scatter of the next); then compound 1; then compound 3.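

In this assay the only edit shown on the phenyl group, the change from phenyl to 4-fluorophenyl, gives a small step (a 1.3-fold higher number from compound 2 to compound 4 (0.12 log units; within the scatter)), so compound 4 cannot be told apart from compound 2 on this read-out. The two earlier steps, made at other places on the molecule, both lay beyond the usual scatter; this one does not, which means that this position, on an aromatic carbon para to a large group, accepts a fluoro without a readable shift in the cell result. Nothing available here explains why the swap makes so little difference.

A single small atom at a single place is thin evidence, and it leaves open whether the position would stay just as quiet with something bigger or very different there, such as an amine, a carboxylic acid or a longer chain like propyl. It also leaves open what a fluoro would do on the other carbons of the same ring, and whether adding it to a compound carrying other changes to the shared core would give the same small step.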